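The compounds below may be only part of what the source reports. "The series", "measured", "known", "first", "only" and "open" are said of these compounds alone.

Compound 1 `O=C1NC(=O)C(Cc2ccc(OCC3CCCCC3)cc2)S1`: 26000 nM
Compound 2 `O=C1NC(=O)C(Cc2ccc(OCC3CC3)cc2)S1`: > 100000 nM

In a functional assay on PC-12 cells (Rattus norvegicus) for inhibition, read by sulforhodamine B assay (on this read-out higher numbers stand for weaker inhibition and lower numbers for stronger inhibition), compound 1 gives 26000 nM. Compound 2 gives > 100000 nM, which is a limit of the assay and not a number. This is the limit of > 100000 nM in this assay, at which 1 of the 2 values shown sits.

The next compound, compound 3 `CCC(C)(C)Oc1ccc(CC2SC(=O)NC2=O)cc1`, keeps the shared core and alters only the side group of compound 2: 1,1-dimethylpropyl in place of cyclopropylmethyl on an oxygen on an aromatic ring. Put simply, 1,1-dimethylpropyl stands in place of cyclopropylmethyl on an oxygen on an aromatic ring, so the group that enters has no ring.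

Going by the values given here, only one measured step bears on this change: an at least 3.8-fold higher number from compound 1 to compound 2 (0.58 log units; beyond the scatter). That step swapped one ring for another and is not the same change, so it guides the expectation only loosely. It does show that the read-out can respond to this side group. A modest shift toward lower numbers is expected, though compound 3 may also end up reported only as a limit.

The expected step is an at least 1.4-fold lower number from compound 2 to compound 3 (0.15 log units; that floor lies within the scatter). For compound 3 the estimated value is 70000 nM, with an expected range from 30000 nM to 150000 nM.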

Compound 3, half-maximal inhibitory concentration: 23000 nM
Compound 3: middle estimate off by 3.0-fold (0.48 log units), on the high side; measured number below the stated range.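

In this assay compound 2 carries a limit of the assay and not a number, and it is the only compound shown that does: the limit of > 100000 nM in this assay, at which 1 of the 3 values shown sits. Even with that limit, the step to the open-chain 1,1-dimethylpropyl group can be read as a floor, an at least 4.3-fold lower number from compound 2 to compound 3 (0.63 log units; beyond the scatter), which shows that a ring in the group on this oxygen is not needed for a measurable value and leaves cyclopropylmethyl as the group that stands apart. Set against the cyclohexylmethyl group, the 1,1-dimethylpropyl group gives a 1.1-fold lower number from compound 1 to compound 3 (0.05 log units; within the scatter), and since this lies within the scatter the two cannot be told apart, even though one group has a ring and the other has none.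

Whether the number of carbons in this group or its branching matters more stays open, as the compounds shown do not separate the two. They also leave open how a straight pentyl chain, or a group holding an amine or a carboxylic acid, would read on this oxygen.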